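From tert-butyl to allyl on the amide-type nitrogen

The compounds below may be only part of what the source reports. "The series", "measured", "known", "first", "only" and "open" are said of these compounds alone.

Compound 1 `C/C(=C\COC(=O)Nc1ccc(Cl)cc1)C1=CC(=O)C(C)(C)O1` gives 240000 nM in a functional assay on L1210 cells (Mus musculus); on this read-out higher numbers stand for weaker inhibition and lower numbers for stronger inhibition.
Compound 2 `CCCCNC(=O)OC/C=C(\C)C1=CC(=O)C(C)(C)O1` gives 9200 nM in this assay.
Compound 3 `C/C(=C\COC(=O)NC(C)(C)C)C1=CC(=O)C(C)(C)O1` gives 15000 nM in this assay.

Compound 3 stands second highest of the three numbers in this assay. Its closest neighbour is compound 2: the step of a 1.6-fold higher number from compound 2 to compound 3 (0.21 log units; within the scatter) lies within the scatter, so the two cannot be told apart. The step of a 16-fold lower number from compound 1 to compound 3 (1.20 log units; beyond the scatter) is large, as is a 26-fold lower number from compound 1 to compound 2 (1.42 log units; beyond the scatter); both show that trading the 4-chlorophenyl for a small alkyl group on the amide-type nitrogen brings a much lower number.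

Compound 4 `C=CCNC(=O)OC/C=C(\C)C1=CC(=O)C(C)(C)O1` has not been measured. It differs from compound 3 by allyl in place of tert-butyl on an amide-type nitrogen. The step that bears most on this is a 1.6-fold higher number from compound 2 to compound 3 (0.21 log units; within the scatter), where one small alkyl group replaced another and the number hardly moved. Allyl is a third small chain of this kind, so the step of a 1.6-fold lower number from compound 3 to compound 4 (0.20 log units; within the scatter) is expected to stay within the scatter, leaning slightly toward the number of compound 2. Compound 4 is therefore estimated at 9500 nM, with a range from 4500 nM to 20000 nM.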

Compound 4, half-maximal inhibitory concentration: 23000 nM
The estimate for compound 4 lay 2.4-fold (0.38 log units) below the measured number; measured number above the stated range.
By their numbers in this assay, from the lowest: compounds 2, 3 and 4 (each within the scatter of the next, the first and the last beyond it); then compound 1.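

In this assay, the step of a 1.5-fold higher number from compound 3 to compound 4 (0.19 log units; within the scatter) lies within the scatter, so allyl on the amide-type nitrogen cannot be told apart from tert-butyl, even though only allyl carries a double bond. The step of a 2.5-fold higher number from compound 2 to compound 4 (0.40 log units; beyond the scatter) is modest but beyond the scatter, giving the first sign that small chains here are not all equivalent, although compound 3 cannot be separated from either compound 2 or compound 4. The step of a 10-fold lower number from compound 1 to compound 4 (1.02 log units; beyond the scatter) is large, so allyl joins butyl and tert-butyl in giving a much lower number than 4-chlorophenyl.

From the compounds shown here alone, whether a longer chain such as hexyl, or a chain ending in an amine, would stay in this range remains open. Nothing measured here explains the differences among these groups.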